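Swapping the N-aryl group of a thiazolidinone series

This account rests on a few compounds, and the source may have more. Where it says the series, first, only, none or still open, it means among the compounds named here.

Compound 1 `COc1ccc(C)cc1N1C(=O)CSC1c1cccc(C(=O)NCCCCc2ccccc2)c1` gives 42% in a functional assay on HOS cells (Homo sapiens) for inhibition, read by CCK-8 assay, with a stated time of 72 h, tested at 1 uM; a higher number here means more inhibition at the concentration tested (going by the name of the read-out), a lower number less inhibition.
Compound 2 `O=C(NCCCCc1ccccc1)c1cccc(C2SCC(=O)N2c2cccc(F)c2)c1` gives 84% in this assay.
Compound 3 `COc1cccc(OC)c1N1C(=O)CSC1c1cccc(C(=O)NCCCCc2ccccc2)c1` gives 80% in this assay.

Among these three numbers compound 3 stands second highest; its nearest neighbour is compound 2, separated by a gap within the scatter, while compound 1 lies far below it, as a number 38 percentage points higher from compound 1 to compound 3 (beyond the scatter) shows. The next compound, compound 4 `COc1c(F)cccc1N1C(=O)CSC1c1cccc(C(=O)NCCCCc2ccccc2)c1`, is not yet measured. It differs from compound 3 in one place: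

3-fluoro-2-methoxyphenyl in place of 2,6-dimethoxyphenyl on an amide-type nitrogen in a ring

Among the measured compounds shown here, three measured steps bear on this position. For the measured compounds named here, both a number 42 percentage points higher from compound 1 to compound 2 (beyond the scatter) and a number 38 percentage points higher from compound 1 to compound 3 (beyond the scatter) were large, and a number 4 percentage points lower from compound 2 to compound 3 (within the scatter) was small, so the two high compounds carry either a fluorine or two methoxy groups, while the single low compound carries one methoxy and a methyl. Compound 4 keeps a methoxy and gains a fluorine, so compound 4 is expected to stay near the high pair, with a number 8 percentage points lower from compound 3 to compound 4 (within the scatter). The estimated value for compound 4 is 72%, between 45% and 90%.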

Compound 4, a percentage reported as inhibition, at one concentration (the size of the read-out at that concentration, not a potency): 9%
Compound 4: middle estimate off by 63 percentage points, on the high side, outside the stated range (below it).
By their numbers in this assay, from the lowest: compound 4; then compound 1; then compounds 3 and 2 (each within the scatter of the next).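

The result shows that this position cannot be read group by group: fluorine and methoxy each appear on a compound with a high value, yet together they give the lowest value of the four. Adding a methoxy to the 3-fluorophenyl ring gives a number 75 percentage points lower from compound 2 to compound 4 (beyond the scatter) in a single change, and the swap from 2,6-dimethoxyphenyl gives a number 71 percentage points lower from compound 3 to compound 4 (beyond the scatter) on the same position. Even the earlier low compound loses ground, with a number 33 percentage points lower from compound 1 to compound 4 (beyond the scatter) for the exchange of its methyl-bearing ring, and no measurement here accounts for these drops.

Open, from the compounds shown here alone, is which part of the 3-fluoro-2-methoxyphenyl group matters. A ring with the methoxy alone, or with chlorine in place of the fluorine or an ethoxy in place of the methoxy, would help separate the two groups.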